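Phenyl in place of cyclopropyl: notes on compound 3

The source may hold more compounds than are shown below. What is called first, only, known or untested is meant among the compounds shown, and "the series" means these compounds.

Measured in a functional assay on HCT-116 cells (Homo sapiens) for cytotoxicity, read by sulforhodamine B assay, with a stated time of 48 h; a lower number here means a stronger inhibitor, a higher number a weaker inhibitor:
- compound 1 `O=C(Nc1nn(C(=O)c2ccccc2)c2c1CN(C(=O)c1ccccc1)C2)c1ccc(F)cc1`: 2780 nM
- compound 2 `COc1ccc(C(=O)Nc2nn(C(=O)C3CC3)c3c2CN(C(=O)c2ccccc2)C3)cc1`: 5180 nM

Only these two values are available so far. Compound 2, at 5180 nM, stands within the usual scatter of compound 1, at 2780 nM, so the two cannot be ranked on these numbers. For the measured compounds named here, no pair of measured compounds differs in a single place, and the series therefore offers no measured step to carry over.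

The next compound is compound 3 `COc1ccc(C(=O)Nc2nn(C(=O)c3ccccc3)c3c2CN(C(=O)c2ccccc2)C3)cc1`, still unmeasured. It differs from compound 2 as follows: phenyl in place of cyclopropyl on a carbonyl carbon. In words, a phenyl stands in place of a cyclopropyl on a carbonyl carbon.

What this change does in this assay has not been measured. No step beyond the scatter is expected, in either direction, since compound 1 at 2780 nM and compound 2 at 5180 nM show no gap beyond it. The expected change is a 1.4-fold lower number from compound 2 to compound 3 (0.13 log units; within the scatter). For compound 3 the estimated value is 3800 nM, with an expected range from 1400 nM to 10000 nM.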

Compound 3, half-maximal inhibitory concentration: 31300 nM
For compound 3 the middle estimate is 8.2-fold (0.92 log units) below the measured one; the measured number lies above the stated range.
By their numbers in this assay, from the lowest: compounds 1 and 2 (each within the scatter of the next); then compound 3.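

In this assay, for the compounds shown here, the substituent on the carbonyl carbon bound to the aromatic nitrogen proves not to be silent: benzoyl in place of cyclopropylcarbonyl gives a 6.0-fold higher number from compound 2 to compound 3 (0.78 log units; beyond the scatter) and is the first single-place step at this position. With benzoyl held constant, methoxy in place of fluoro on an aromatic carbon gives an 11-fold higher number from compound 1 to compound 3 (1.05 log units; beyond the scatter) so the aromatic substituent matters too, and both steps reach a higher number at compound 3, which the two earlier values alone could not reveal. No measurement on hand accounts for either step.

On these data alone, whether the rise follows the aromatic ring itself or simply the larger group remains open, and cyclohexylcarbonyl or acetyl on the same carbonyl carbon would help to separate those readings. Also open, as far as these compounds go, is whether the fluoro and methoxy step keeps its size with cyclopropylcarbonyl in place of benzoyl, and whether a hydroxyl or an amine on that aromatic ring would move the number in either direction.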